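A Methoxy Group Added to Compound 2

A few compounds are considered here, and "the series" means these few. Any claim that something is new, unique, unknown or untested is made for them only; others in the source may bear on it.

In a functional assay on MCF7 cells (Homo sapiens) for antiproliferative activity, read by sulforhodamine B assay, with a stated time of 72 h (a higher number here means a weaker inhibitor, a lower number a stronger inhibitor), compound 1 `O=C1CS/C(=N/Nc2nncc3ccccc23)N1c1ccccc1` gives 77 nM and compound 2 `S=C(NNc1nncc2ccccc12)Nc1ccccc1` gives 47 nM while compound 3 `O=S(=O)(Nc1nccs1)c1ccc(Nc2nncc3ccccc23)cc1` gives 55 nM in the same read-out. Compound 2 thus lies within the usual scatter of both others, nearest to compound 3 and furthest from compound 1. Compound 4 `COc1ccc(NC(=S)NNc2nncc3ccccc23)cc1` differs from compound 2 by methoxy in place of hydrogen on an aromatic carbon in one place: methoxy in place of hydrogen on an aromatic carbon, para to a large group. Going by the values given here, no two measured compounds differ in one place, so nothing shows this change directly. In this assay no shift beyond the scatter is expected in either direction. The estimated change a 1.1-fold higher number from compound 2 to compound 4 (0.03 log units; within the scatter) is expected to stay inside that scatter. Compound 4 is expected near 50 nM with an estimated range from 20 nM to 130 nM as the likely span.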

Compound 4, half-maximal inhibitory concentration: 60 nM
The estimate for compound 4 lay 1.2-fold (0.08 log units) below the measured number, and the stated range covers the measured number.
By their numbers in this assay, from the lowest: compounds 2, 3, 4 and 1 (each within the scatter of the next).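

In this assay the change to methoxy in place of hydrogen on an aromatic carbon, para to a large group, gives a 1.3-fold higher number from compound 2 to compound 4 (0.11 log units; within the scatter) and is the first single-place step among these compounds. This position therefore takes methoxy, with its two heavy atoms, without a shift that can be told from the scatter. Nothing measured here offers an explanation for this result.

On these data alone, whether an amine or a carboxylic acid at this position would also stay within the scatter remains open. So does whether methoxy would read the same on another carbon of this ring.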